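Swapping an alkyl hydroxamate for a benzyl one

This account rests on a few compounds, and the source may have more. Where it says the series, first, only, none or still open, it means among the compounds named here.

Compound 2 `O=C(CCCC(=O)Nc1ccc(NC(=O)Nc2ccc(Cl)c(C(F)(F)F)c2)cc1)NO` shares its core with compound 1 `O=C(CCCCCCC(=O)Nc1ccc(NC(=O)Nc2ccc(Cl)c(C(F)(F)F)c2)cc1)NO` and differs only in chain length. In a functional assay on A549 cells (Homo sapiens) for inhibition, read by sulforhodamine B assay, with a stated time of 48 h (a higher number here means a weaker inhibitor, a lower number a stronger inhibitor), compound 2 gives > 10000 nM, which is a limit of the assay rather than a number. Compound 1 gives 9500 nM in this assay. Going by the values given here, the one measured step, an at least 1.0-fold higher number from compound 1 to compound 2 (0.02 log units; that floor lies within the scatter), is bounded by the limit of > 10000 nM in this assay, at which 1 of the 2 values shown sits, and lies within the scatter. Compound 3 `O=C(Nc1ccc(NCc2ccc(C(=O)NO)cc2)cc1)Nc1ccc(Cl)c(C(F)(F)F)c1` differs from compound 2 by 4-(hydroxycarbamoyl)benzyl in place of (3-(hydroxycarbamoyl)propyl)carbonyl on a nitrogen on an aromatic ring. Among the compounds with values here, no measured step tests such a change, so direction is uncertain. Compound 3 is expected near 5000 nM, between 1000 nM and 20000 nM. That amounts to an expected step of an at least 2.0-fold lower number from compound 2 to compound 3 (0.30 log units; that floor lies within the scatter).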

Compound 3, half-maximal inhibitory concentration: 4300 nM
Compound 3: the middle estimate sits 1.2-fold (0.07 log units) above what was measured; the measured number falls inside the stated range.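

On the nitrogen on an aromatic ring, 4-(hydroxycarbamoyl)benzyl in place of (3-(hydroxycarbamoyl)propyl)carbonyl gives an at least 2.3-fold lower number from compound 2 to compound 3 (0.36 log units; beyond the scatter) in this assay, the first change shown here that clears the scatter. That size is only a floor, as compound 2 sits at a limit of the assay: the limit of > 10000 nM in this assay, at which 1 of the 3 values shown sits.

The change brings in an aromatic ring and removes a carbonyl in one move, so the compounds shown cannot say which of the two matters. A 4-(hydroxycarbamoyl)benzoyl group on that nitrogen, which has both the ring and the carbonyl, would separate them.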